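Swapping the benzyl substituent on a shared core: cytotoxicity outlook

The source may hold more compounds than are shown below. What is called first, only, known or untested is meant among the compounds shown, and "the series" means these compounds.

Compound 1, `COc1cc(-c2nnc(SCc3ccc(C)cc3)o2)ccc1O`, gives 549000 nM in an ADME assay on cells (Mus musculus, strain BALB/c) for cytotoxicity, read by MTT assay, with a stated time of 24 h; on this read-out lower numbers stand for higher toxicity in this test and higher numbers for lower toxicity in this test. Compound 2, `COc1cc(-c2nnc(SCc3ccc(F)cc3F)o2)ccc1O`, gives 520000 nM in this assay, and the step of a 1.1-fold lower number from compound 1 to compound 2 (0.02 log units; within the scatter) shows the two compounds within the scatter of each other. Within the data shown here, compound 2 therefore holds the lowest of the two numbers so far, but its nearest neighbour, compound 1, lies so close that no order between them can be read.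

Compound 3, `COc1cc(-c2nnc(SCc3ccccc3Br)o2)ccc1O`, is not yet measured. It differs from compound 2 only by 2-bromophenyl in place of 2,4-difluorophenyl on a saturated chain carbon bound to a sulfur. Among the measured compounds shown here, the one measured step that bears on this, the step from compound 1 to compound 2, changed the same group at the same place and stayed within the scatter. A similar outcome is expected here, so the step of a 1.0-fold higher number from compound 2 to compound 3 (0.01 log units; within the scatter) is estimated to stay within the scatter. For compound 3 the expected value in this assay is 530000 nM, with a range from 250000 nM to 1100000 nM.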

Compound 3, half-maximal cytotoxic concentration: 363000 nM
Beside the measured number, compound 3's estimate is 1.5-fold (0.16 log units) above it; the measured number falls inside the stated range.
By their numbers in this assay, from the lowest: compounds 3, 2 and 1 (each within the scatter of the next).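

In this assay, replacing the group gives a 1.4-fold lower number from compound 2 to compound 3 (0.16 log units; within the scatter), and the comparison with the remaining compound gives a 1.5-fold lower number from compound 1 to compound 3 (0.18 log units; within the scatter). Among these compounds, the earlier pair showed this for only two groups; now three differently substituted phenyl rings on a saturated chain carbon bound to a sulfur, carrying methyl, two fluorines or one bromine, cannot be told apart in this test. No available evidence bears on these results.

All three compounds keep a substituted phenyl ring at this place and share the same core, so they cannot show whether the read-out would hold with something quite different there. An amine, a carboxylic acid or a longer chain in place of the ring could give a clearly different number, and these three compounds offer no guide to that.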